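Chloro to bromo: a one-atom change on a phenyl ring

A few compounds are considered here, and "the series" means these few. Any claim that something is new, unique, unknown or untested is made for them only; others in the source may bear on it.

Compound 1 `O=C(Nc1ncc([N+](=O)[O-])s1)c1ccc([N+](=O)[O-])o1`: 67.3%
Compound 2 `O=C(Nc1ncc([N+](=O)[O-])s1)c1ccc(-c2ccc(Cl)cc2)o1`: 74.1%

Of the compounds shown here, two have been measured in an ADME assay on HEK-293T cells (Homo sapiens) for cytotoxicity, read by MTT assay, tested at 100 uM; on this read-out higher numbers stand for a weaker effect at the one concentration tested and lower numbers for a stronger effect. Compound 1 gives 67.3% and compound 2 gives 74.1%. Among the measured compounds shown here, the one measured step, a number 6.8 percentage points higher from compound 1 to compound 2 (within the scatter), exchanged a nitro group for a 4-chlorophenyl group and stayed within the scatter, so the two compounds cannot be told apart on this read-out. Compound 2 therefore stands level with compound 1, neither clearly weaker nor clearly stronger in cytotoxicity.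

Compound 3 `O=C(Nc1ncc([N+](=O)[O-])s1)c1ccc(-c2ccc(Br)cc2)o1` has not yet been measured. Its change from compound 2 is bromo in place of chloro on an aromatic carbon. For the measured compounds named here, no measured step bears directly on swapping one halogen for another; the only step available concerned a different group and was itself within the scatter. With nothing pointing in either direction, the estimated step of a number 0.1 percentage points lower from compound 2 to compound 3 (within the scatter) is expected to remain within the scatter. Compound 3 is therefore estimated at 74%, in a range from 60% to 88%.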

Compound 3, a percentage reported as activity, at one concentration (the size of the read-out at that concentration, not a potency): 70.3%
Compound 3: the middle estimate sits 3.7 percentage points above what was measured; the measured number falls inside the stated range.
By their numbers in this assay, from the lowest: compounds 1, 3 and 2 (each within the scatter of the next).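

In this assay, bromo in place of chloro on the six-membered aromatic ring, para to a large group, gives a number 3.8 percentage points lower from compound 2 to compound 3 (within the scatter), so the two halogens cannot be told apart at this position on this read-out. Exchanging nitro for 4-bromophenyl on the core gives a number 3 percentage points higher from compound 1 to compound 3 (within the scatter), which means that a second aryl group carrying a different halogen also leaves the reading inside the usual scatter, and all three compounds now stand level with one another. No measurement here offers any explanation for how closely these numbers agree.

What remains open is whether any group at this place on the phenyl ring can move the number beyond the scatter, since the halogens shown are only chloro and bromo, and an amine or a carboxylic acid there could read quite differently. Each compound also has a reading at only one concentration, so how strongly any of them acts on these cells across a range of concentrations is still an open question.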